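Trifluoromethyl to Dichloro on the Pendant Phenyl Ring

The compounds below may be only part of what the source reports. "The series", "measured", "known", "first", "only" and "open" are said of these compounds alone.

Compound 1 `Cc1ccc(-c2ccnc(Nc3ccc4c(c3)c(/C=C3/C(=O)Nc5ccccc53)cn4C)n2)cc1` in a functional assay on MCF7 cells (Homo sapiens) for cytotoxicity, read by MTT assay, with a stated time of 48 h (a higher number here means a weaker inhibitor, a lower number a stronger inhibitor), gives > 100000 nM, which is a limit of the assay rather than a number. Compound 2 `Cn1cc(/C=C2/C(=O)Nc3ccccc32)c2cc(Nc3nccc(-c4ccc(Cl)cc4)n3)ccc21` in this assay gives 23500 nM. Compound 3 `Cn1cc(/C=C2/C(=O)Nc3ccccc32)c2cc(Nc3nccc(-c4ccc(C(F)(F)F)cc4)n3)ccc21` in this assay gives 65200 nM.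

Among the two compounds with a number, compound 3 stands highest; its nearest neighbour is compound 2, and the difference is a 2.8-fold higher number from compound 2 to compound 3 (0.44 log units; beyond the scatter). Compound 1 sits at the limit of > 100000 nM in this assay, at which 1 of the 3 values shown sits, so its steps to the others are floors only: an at least 4.2-fold lower number from compound 1 to compound 2 (0.62 log units; beyond the scatter) and an at least 1.5-fold lower number from compound 1 to compound 3 (0.18 log units; that floor lies within the scatter).

Compound 4 `Cn1cc(/C=C2/C(=O)Nc3ccccc32)c2cc(Nc3nccc(-c4ccc(Cl)cc4Cl)n3)ccc21` differs from compound 3 in one place: 2,4-dichlorophenyl in place of 4-(trifluoromethyl)phenyl on an aromatic carbon. The most relevant measured step is the one between chloro and trifluoromethyl on the same ring, a 2.8-fold higher number from compound 2 to compound 3 (0.44 log units; beyond the scatter), which ran from the lower number of compound 2 to the higher number of compound 3. Compound 4 carries chloro in that position again, with a second chloro added, so a modest move back toward the number of compound 2 is expected rather than a change beyond the scatter in the other direction. Compound 4 is therefore estimated at 20000 nM, with a range from 6000 nM to 65000 nM. The step that this estimate implies is a 3.3-fold lower number from compound 3 to compound 4 (0.51 log units; beyond the scatter), an expected change and not a measured one.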

Compound 4, half-maximal inhibitory concentration: > 100000 nM
Compound 4 was reported as a limit (the forecaster's own chance of this, stated with the estimate: 15%); middle value at least 5.0-fold (0.69 log units) away from the limit.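

The clearest new information comes from adding one chloro to the pendant phenyl ring of compound 2, in place of a hydrogen, which in this assay gives an at least 4.2-fold higher number from compound 2 to compound 4 (0.62 log units; beyond the scatter). Among the compounds shown here, the earlier compounds varied only a single group on that ring, so this is the first sign that a second chloro can push the number up rather than merely shift it among single groups. Set against the trifluoromethyl compound, the change to 2,4-dichlorophenyl gives an at least 1.5-fold higher number from compound 3 to compound 4 (0.18 log units; that floor lies within the scatter), so these two compounds cannot be put in order, and since compound 4 and compound 1 are both reported as limits, not numbers, the step between them cannot be read: the limit of > 100000 nM in this assay, at which 2 of the 4 values shown sit.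

On these data alone, how far compound 4 lies past its limit remains open, as does whether the rise belongs to this added chloro in particular or would come with any second group on the ring. An amine or a carboxylic acid on the pendant phenyl ring, in place of the chloro, would be needed to tell whether this position accepts anything beyond the groups shown here.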